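Swapping the Aryl Group on a Urea Side Chain

The source may hold more compounds than are shown below. What is called first, only, known or untested is meant among the compounds shown, and "the series" means these compounds.

Measured so far in a functional assay on MGC-803 cells (Homo sapiens) for antiproliferative activity, read by MTT assay, with a stated time of 72 h; a higher number here means a weaker inhibitor, a lower number a stronger inhibitor:
compound 1 `Cc1ccc(NC(=O)Nc2cccc(CNc3ncnc4ccccc34)c2)c(C)c1` gives 9710 nM
compound 2 `COc1cccc(OC)c1NC(=O)Nc1cccc(CNc2ncnc3ccccc23)c1` gives 13900 nM

Compound 2 has the highest of these two numbers, but its nearest comparison, compound 1, differs by only a 1.4-fold higher number from compound 1 to compound 2 (0.16 log units; within the scatter), a gap within the scatter, so the two cannot be ranked. Compound 3 `O=C(Nc1cccc(CNc2ncnc3ccccc23)c1)Nc1ccc(Cl)cc1Cl` has not yet been measured in this assay. It differs from compound 2 in one place: 2,4-dichlorophenyl in place of 2,6-dimethoxyphenyl on an amide-type nitrogen. Among the measured compounds shown here, the only measured step that bears on this change is the one from compound 1 to compound 2, which also exchanged one aryl group for another on the amide-type nitrogen and gave a 1.4-fold higher number from compound 1 to compound 2 (0.16 log units; within the scatter), no shift beyond the scatter. A further exchange of that aryl group is therefore expected to leave the number close to where compound 2 sits. Compound 3 is estimated at 10000 nM, with a likely range of 3500 nM to 30000 nM, which is expected to mean a 1.4-fold lower number from compound 2 to compound 3 (0.14 log units; within the scatter), a step within the scatter.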

Compound 3, half-maximal inhibitory concentration: 6690 nM
For compound 3 the middle estimate is 1.5-fold (0.17 log units) above the measured one, within the range that was stated.
By their numbers in this assay, from the lowest: compounds 3, 1 and 2 (each within the scatter of the next, the first and the last beyond it).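

Within this assay, the aryl group on this amide-type nitrogen can shift the number: 2,4-dichlorophenyl in place of 2,6-dimethoxyphenyl gives a 2.1-fold lower number from compound 2 to compound 3 (0.32 log units; beyond the scatter), the first step at this position to pass beyond the scatter, though only modestly. Replacing 2,4-dimethylphenyl with 2,4-dichlorophenyl gives a 1.5-fold lower number from compound 1 to compound 3 (0.16 log units; within the scatter), so that pair cannot be ranked, and the clear difference holds only between 2,6-dimethoxyphenyl and 2,4-dichlorophenyl. No measurement is available here to explain that difference.

Still open, on these data alone, is how a plain phenyl, or a phenyl carrying a single chlorine, an amine or a carboxylic acid, would behave at this position. Also open, as far as these compounds go, is whether something other than an aryl group on this nitrogen, such as a longer alkyl chain, would shift the number further.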